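The compounds below may be only part of what the source reports. "The series", "measured", "known", "first", "only" and "open" are said of these compounds alone.

In an ADME assay on A549 cells (Homo sapiens) for cytotoxicity, read by resazurin assay, with a stated time of 48 h (on this read-out lower numbers stand for higher toxicity in this test and higher numbers for lower toxicity in this test), compound 1 `CCCNc1ccc(NC(=O)c2cc(Cl)ccc2O)c(Cl)c1` gives 22500 nM, the lowest of the three measured numbers, against compound 2 `CN(C)c1ccc(NC(=O)c2cc(Cl)ccc2O)c(Cl)c1` at 85100 nM and compound 3 `CCN(CC)c1ccc(NC(=O)c2cc(Cl)ccc2O)c(Cl)c1` at 55500 nM. Compound 4 `O=C(Nc1ccc(NCc2ccc(C(F)(F)F)cc2)cc1Cl)c1cc(Cl)ccc1O` has not yet been measured. It differs from compound 1 by 4-(trifluoromethyl)phenyl in place of ethyl on a saturated chain carbon bound to a nitrogen on an aromatic ring.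

Among the measured compounds shown here, two measured steps bear on this change, since both alter the same amino group: a 3.8-fold higher number from compound 1 to compound 2 (0.58 log units; beyond the scatter) and a 2.5-fold higher number from compound 1 to compound 3 (0.39 log units; beyond the scatter). Both are modest and both go upward, while a 1.5-fold lower number from compound 2 to compound 3 (0.19 log units; within the scatter) separates nothing. None of these steps brings in a ring, so they offer only a loose guide. Compound 4 keeps the chain carbon on the nitrogen, and a modest move to a lower number in this assay is expected, though with wide uncertainty. The expected change is a 2.5-fold lower number from compound 1 to compound 4 (0.40 log units; beyond the scatter). Compound 4 is estimated at 9000 nM, with an expected range from 2500 nM to 30000 nM.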

Compound 4, half-maximal cytotoxic concentration: 62700 nM
Beside the measured number, compound 4's estimate is 7.0-fold (0.84 log units) below it; measured number above the stated range.
By their numbers in this assay, from the lowest: compound 1; then compounds 3, 4 and 2 (each within the scatter of the next).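

In this assay, the step to the much larger 4-(trifluoromethyl)phenyl in place of ethyl gives a 2.8-fold higher number from compound 1 to compound 4 (0.45 log units; beyond the scatter) and so moves the number upward, the same direction as the two earlier changes at this amino group. Those earlier changes both put two alkyl groups on the nitrogen, whereas compound 4 keeps a single substituent there, so the upward move does not depend on that feature, and compound 1 remains the lowest of the four. Nothing here gives a measured reason for this rise.

The compounds shown do not separate the contribution of the aromatic ring from that of the trifluoromethyl group, which an unsubstituted phenyl at the same chain carbon would address. Also open, on these data alone, is how a carboxylic acid or a basic amine on that ring would read in this test.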